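Amide variation on the diaryl aminothiophene core: notes

A few compounds are considered here, and "the series" means these few. Any claim that something is new, unique, unknown or untested is made for them only; others in the source may bear on it.

Measured so far:
compound 1 `CC1CN(C(=O)c2c(N)sc(-c3ccc(Cl)cc3)c2-c2ccc(Cl)cc2)CCN1` — 4930 nM
compound 2 `CC(C)CNC(=O)c1c(N)sc(-c2ccc(Cl)cc2)c1-c1ccc(Cl)cc1` — 21000 nM
compound 3 `CN1CCN(C(=O)c2c(N)sc(-c3ccc(Cl)cc3)c2-c2ccc(Cl)cc2)CC1` — 590 nM

All three numbers come from a functional assay on A549 cells (Homo sapiens) for inhibition, read by sulforhodamine B assay, with a stated time of 72 h; on this read-out higher numbers stand for weaker inhibition and lower numbers for stronger inhibition. Compound 1 holds the second highest of the three numbers: compound 2 sits above it, a 4.3-fold higher number from compound 1 to compound 2 (0.63 log units; beyond the scatter), and compound 3 below it, an 8.4-fold lower number from compound 1 to compound 3 (0.92 log units; beyond the scatter). Between compound 2 and compound 3 the gap is the widest of the set, a 36-fold lower number from compound 2 to compound 3 (1.55 log units; beyond the scatter).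

Compound 4 `Nc1sc(-c2ccc(Cl)cc2)c(-c2ccc(Cl)cc2)c1C(=O)N1CCC(=O)CC1=O` has not been measured. It differs from compound 1 at the carbonyl carbon whose other neighbour is an aromatic carbon: 2,4-dioxopiperidin-1-yl in place of 3-methylpiperazin-1-yl on a carbonyl carbon.

Among the compounds with values here, two measured steps touch the same carbonyl position. Replacing the 3-methylpiperazin-1-yl group by isobutylamino gave a 4.3-fold higher number from compound 1 to compound 2 (0.63 log units; beyond the scatter), while shifting the methyl within the ring to 4-methylpiperazin-1-yl gave an 8.4-fold lower number from compound 1 to compound 3 (0.92 log units; beyond the scatter). The change to compound 4 removes the 3-methylpiperazin-1-yl ring altogether, as the step to compound 2 did, rather than keeping it, as the step to compound 3 did; the number is therefore expected to move upward in this assay, by a step of roughly a 3.0-fold higher number from compound 1 to compound 4 (0.48 log units; beyond the scatter). For compound 4 the expected value is 15000 nM, with a range from 4000 nM to 50000 nM.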

Compound 4, half-maximal inhibitory concentration: 4090 nM
Estimate against measurement, compound 4: 3.7-fold (0.56 log units) above, within the range that was stated.
By their numbers in this assay, from the lowest: compound 3; then compounds 4 and 1 (each within the scatter of the next); then compound 2.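

In this assay, 2,4-dioxopiperidin-1-yl and 3-methylpiperazin-1-yl cannot be told apart on this carbonyl carbon: a 1.2-fold lower number from compound 1 to compound 4 (0.08 log units; within the scatter). A six-membered ring with only the amide nitrogen as its hetero atom and two added carbonyl groups therefore matches the methylpiperazine isomer with the methyl group in the 3-position, while the other two amides remain distinct: a 6.9-fold higher number from compound 3 to compound 4 (0.84 log units; beyond the scatter), and a 5.1-fold lower number from compound 2 to compound 4 (0.71 log units; beyond the scatter). No measurement on hand accounts for these steps.

The compounds shown leave open whether the low number of compound 3 depends on the methyl group itself, which unsubstituted piperazin-1-yl or 4-ethylpiperazin-1-yl could test. Morpholin-4-yl or piperidin-1-yl on the same carbonyl carbon would show how the series behaves with a simple ring lacking the two carbonyl groups of compound 4.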